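The source may report more compounds than this note shows. Statements on the series, on what has been measured and on what is new or still open speak of the compounds shown alone.

Working notes on the series.

Going by the values given here, compound 1 `O=C1O[C@H]([C@@H](O)Cn2cc(CNS(=O)(=O)c3ccc(F)cc3)nn2)C(OCc2ccccc2)=C1OCc1ccccc1` is the only member with a numerical result: in a functional assay on SW-620 cells (Homo sapiens) for antiproliferative activity, read by MTT assay, with a stated time of 72 h (on this read-out higher numbers stand for weaker inhibition and lower numbers for stronger inhibition), compound 1 gives 41100 nM. Among the compounds with values here, compound 2 `COc1ccccc1-c1cn(C/C=C2\OC(=O)C(OCc3ccccc3)=C2OCc2ccccc2)nn1` returns only a limit of the assay, > 100000 nM, which is recorded in the limit of > 100000 nM in this assay, at which 1 of the 2 values shown sits; this is not a number and supports no step. Within the data shown here, no pair that differs in one place has been measured, so the numbers so far give no measured size for any change, and compound 1 simply stands as the one quantified point while compound 2 sits at the limit.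

Compound 3 `COc1ccc(-c2cn(C[C@H](O)[C@H]3OC(=O)C(OCc4ccccc4)=C3OCc3ccccc3)nn2)cc1` is not yet measured. It differs from compound 1 as follows: 4-methoxyphenyl in place of (((4-fluorophenyl)sulfonyl)amino)methyl on an aromatic carbon. Among the measured compounds shown here, with no measured step to lean on, the expectation for this change in this assay is a weak-to-moderate loss, but one that may well stay within the scatter. For compound 3 the step from compound 1, a 1.5-fold higher number from compound 1 to compound 3 (0.16 log units; within the scatter), is an estimate only. Compound 3 is expected to give about 60000 nM, with a plausible range from 15000 nM to 200000 nM, and a real chance that only a limit is reported.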

Compound 3, half-maximal inhibitory concentration: 58200 nM
For compound 3 the middle estimate is 1.0-fold (0.01 log units) above the measured one; the measured number falls inside the stated range.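

In this assay, going by these compounds alone, the first measured step at this aromatic carbon of the five-membered ring, 4-methoxyphenyl in place of (((4-fluorophenyl)sulfonyl)amino)methyl, is a 1.4-fold higher number from compound 1 to compound 3 (0.15 log units; within the scatter). Compound 3 thus gives a second quantified point, and for this pair a numerical result does not depend on the sulfonyl group or on the hydrogen-bond donor of the group that leaves, since the group that enters carries neither. No measurement shown gives a cause for this result, and the step says only that these two quite different groups cannot be told apart on this read-out.

Going by these compounds, whether an amine or a carboxylic acid on this aromatic carbon, or a longer chain between it and the benzene ring, would move the number beyond the scatter remains open. Also open, on these data alone, is what an unsubstituted phenyl would give at this carbon, and what part the hydroxyl group shared by compound 1 and compound 3 plays in their values.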